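Chain terminus variation on the shared core: compound 3

The compounds below may be only part of what the source reports. "The series", "measured", "known", "first", "only" and "open" are said of these compounds alone.

Compound 1 `Cn1c(Cc2nn(CCCO)c(=O)c3ccccc23)nnc1SCC(=O)Nc1ccc(Cl)cc1Cl` and compound 2 `Cn1c(Cc2nn(CCC(=O)O)c(=O)c3ccccc23)nnc1SCC(=O)Nc1ccc(Cl)cc1Cl` share a core and differ only at the chain on the aromatic nitrogen. In an assay on NK92 cells for inhibition of interleukin-2 (Homo sapiens), read by AlphaScreen, with stated times of 30 min and 1 h (on this read-out higher numbers stand for weaker inhibition and lower numbers for stronger inhibition), compound 1 gives > 30000 nM, which is a limit of the assay and not a number. In this assay compound 2 likewise gives > 30000 nM, again a limit. The step that the two limits leave unreadable from compound 1 to compound 2 is therefore unreadable; the limit of > 30000 nM in this assay, at which 2 of the 2 values shown sit, marks where both values sit. Compound 2 thus stands at the limit, with no numbered value anywhere in the series to compare against.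

Compound 3 `CN(C)CCCn1nc(Cc2nnc(SCC(=O)Nc3ccc(Cl)cc3Cl)n2C)c2ccccc2c1=O` is not yet measured. It differs from compound 2 by (dimethylamino)methyl in place of carboxy on a saturated chain carbon, two bonds along the chain from an aromatic nitrogen. Going by the values given here, the only measured step, from compound 1 to compound 2, touches the same region of the chain but is unreadable, so it gives no size to carry forward. Nothing in the series points to a step beyond the scatter in either direction in this assay. Compound 3 is therefore expected to remain at or near the limit, estimated as 30000 nM with a range from 8000 nM to 100000 nM. This estimate means an expected step of a number no higher from compound 2 to compound 3 (the limit leaves the size open).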

Compound 3, half-maximal inhibitory concentration: > 30000 nM
Compound 3: a limit, no number; the forecaster's own chance of this, stated with the estimate: 80%; the middle value lies on the limit itself.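

In this assay compound 3 gives > 30000 nM, a limit and not a number, so its steps from compound 1 and compound 2 cannot be read: the limit of > 30000 nM in this assay, at which 3 of the 3 values shown sit. The compounds shown leave open whether any terminus on the chain at the aromatic nitrogen gives a numbered value in this assay, and how large a step at that chain could be.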